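A few compounds are considered here, and "the series" means these few. Any claim that something is new, unique, unknown or untested is made for them only; others in the source may bear on it.

Working notes on the series, followed in an ADME assay on CCD-1095SK cells (Homo sapiens) for antiproliferative activity, read by crystal violet staining, with a stated time of 96 h; on this read-out higher numbers stand for an effect only at larger amounts of compound and lower numbers for an effect already at smaller amounts. Compound 1 (`O[C@@H]1[C@@H](O)[C@H](Oc2ccc3ccccc3c2)OC[C@H]1F`) gives 32 uM. Compound 2 (`O[C@@H]1CO[C@@H](Oc2ccc3ccccc3c2)C[C@H]1O`) gives 19 uM. Within the data shown here, these two values lie within the usual scatter of each other, so the numbers so far do not separate compound 2 from compound 1.

Next in line is compound 3 (`CO[C@H]1[C@H](Oc2ccc3ccccc3c2)OC[C@@H](O)[C@@H]1O`). It departs from compound 2 by a single change: methoxy in place of hydrogen on a saturated ring carbon. This is methoxy in place of hydrogen on a saturated ring carbon, next to the ring atom that bears a hydroxy group and next to the ring atom that bears a large group.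

Among the measured compounds shown here, no measured pair differs in one place only, so the data offer no direct precedent for this change. The expectation rests on compound 2 at 19 uM alone, with a wide margin. No step beyond the scatter is expected in this assay, though a slightly higher number is the likelier direction. The estimated 1.5-fold higher number from compound 2 to compound 3 (0.17 log units; within the scatter) stays within the scatter. For compound 3 the expected value is 28 uM, with an estimated range from 12 uM to 65 uM.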

Compound 3, concentration for half-maximal effect: 55 uM
Beside the measured number, compound 3's estimate is 2.0-fold (0.29 log units) below it; the measured number falls inside the stated range.
By their numbers in this assay, from the lowest: compounds 2, 1 and 3 (each within the scatter of the next, the first and the last beyond it).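

In this assay, among these compounds, methoxy in place of hydrogen on this saturated ring carbon gives a 2.9-fold higher number from compound 2 to compound 3 (0.46 log units; beyond the scatter) and so provides the first step between compounds that differ in one place. The step is modest but lies beyond the scatter, which shows that this ring carbon, next to the ring atom that bears a hydroxy group and next to the ring atom that bears a large group, is not indifferent to substitution on this read-out. The direction is toward an effect only at larger amounts of compound, and no accompanying measurement bears on this result.

The compounds shown leave open whether the step belongs to methoxy in particular or would follow any group placed on this ring carbon, a question that an amine, an ethoxy group or a carboxylic acid at the same place could settle. They also leave open whether methoxy on another saturated ring carbon of the shared core would give a step of similar size and direction.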